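Swapping Pyridin-2-yl for 2-Methoxyphenyl in Compound 1

The source may hold more compounds than are shown below. What is called first, only, known or untested is meant among the compounds shown, and "the series" means these compounds.

Going by the values given here, compound 1 `O=C(CN1CCN(c2ccccn2)CC1)Nc1nc2ccccc2[nH]1` is one of two compounds measured so far. In a functional assay, read by spectrophotometry, with a stated time of 30 min, tested at 5 ug/mL (a higher number here means a stronger effect of the compound at the concentration tested, a lower number a weaker effect), compound 1 gives 30.8%. Among the compounds with values here, its only measured neighbour is compound 2 `O=C(CN1CCN(c2ccc([N+](=O)[O-])cc2)CC1)Nc1nc2ccccc2[nH]1`, in which 4-nitrophenyl replaces pyridin-2-yl on the amine nitrogen in the ring. In this assay compound 2 gives 16.1%, and the step of a number 14.7 percentage points lower from compound 1 to compound 2 (beyond the scatter) lies beyond the scatter, so compound 1 stands highest of the two numbers shown.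

Compound 3 `COc1ccccc1N1CCN(CC(=O)Nc2nc3ccccc3[nH]2)CC1` has not been measured. It differs from compound 1 in one place: 2-methoxyphenyl in place of pyridin-2-yl on an amine nitrogen in a ring. Within the data shown here, this change resembles the one measured step, since in both cases pyridin-2-yl gives way to a six-membered aromatic ring of carbon only carrying a single substituent. That step, a number 14.7 percentage points lower from compound 1 to compound 2 (beyond the scatter), was a modest drop. The entering group here is a different one, so that step is only a rough guide, and a decrease of similar or somewhat smaller size is expected. For compound 3 the expected step is a number 10.8 percentage points lower from compound 1 to compound 3 (beyond the scatter). Compound 3 is therefore estimated at 20%, with a range from 8% to 34%.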

Compound 3, a percentage reported as activity, at one concentration (the size of the read-out at that concentration, not a potency): 10.8%
Compound 3: the middle estimate sits 9.2 percentage points above what was measured; measured number inside the range.
By their numbers in this assay, from the lowest: compounds 3 and 2 (each within the scatter of the next); then compound 1.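

In this assay, a second replacement of pyridin-2-yl on this amine nitrogen in a ring also lowers the number: the change to 2-methoxyphenyl gives a number 20 percentage points lower from compound 1 to compound 3 (beyond the scatter). Exchanging 4-nitrophenyl for 2-methoxyphenyl gives a number 5.3 percentage points lower from compound 2 to compound 3 (within the scatter), so these two groups cannot be told apart in this assay, and among these three compounds the one ring with a hetero atom, pyridin-2-yl, goes with the highest number while the two carbon-only rings stand at a similar level. Nothing shown here gives a reason for the drop on leaving pyridin-2-yl.

These three compounds leave open whether the ring nitrogen of pyridin-2-yl is what matters, and a plain phenyl ring or a pyridin-4-yl ring on the same amine nitrogen would help to separate the ring itself from its substituent or from where its nitrogen sits. They also leave open whether an aromatic ring is needed here at all, a question that a cyclohexyl ring or a simple methyl group in this place could address.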